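The source may report more compounds than this note shows. Statements on the series, on what has been measured and on what is new or still open speak of the compounds shown alone.

In a functional assay on DU-145 cells (Homo sapiens) for inhibition (on this read-out higher numbers stand for weaker inhibition of growth and lower numbers for stronger inhibition of growth), compound 1 `O=S(=O)(/C=C/c1ccccc1)Cc1ccc(Nc2ncnc3ccccc23)cc1` gives 2000 nM, compound 2 `O=S(=O)(/C=C/c1ccc(F)cc1)Cc1ccc(Nc2ncnc3ccccc23)cc1` gives 300 nM and compound 3 `O=S(=O)(/C=C/c1ccc(O)cc1)Cc1ccc(Nc2ncnc3ccccc23)cc1` gives 19000 nM, the highest of the three numbers. Compound 4 `O=S(=O)(/C=C/c1ccc(O)cc1)Cc1ccc(Nc2ncnc3ccc(Br)cc23)cc1` differs from compound 3 by one change: bromo in place of hydrogen on an aromatic carbon. Among the measured compounds shown here, no measured step touches that place. Elsewhere, the data show a 9.5-fold higher number from compound 1 to compound 3 (0.98 log units; beyond the scatter) for hydroxy in place of hydrogen and a 63-fold higher number from compound 2 to compound 3 (1.80 log units; beyond the scatter) for hydroxy in place of fluoro. Only the fluoro step, a 6.7-fold lower number from compound 1 to compound 2 (0.82 log units; beyond the scatter), adds a halogen, so a modest step to a lower number is expected, with much uncertainty. The estimated step is a 2.7-fold lower number from compound 3 to compound 4 (0.43 log units; beyond the scatter). In this assay, compound 4 is expected at 7000 nM, with an estimated range of 1500 nM to 25000 nM.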

Compound 4, concentration for 50% growth inhibition: 3000 nM
For compound 4 the middle estimate is 2.3-fold (0.37 log units) above the measured one; low and high end bracket the measured number.
By their numbers in this assay, from the lowest: compound 2; then compounds 1 and 4 (each within the scatter of the next); then compound 3.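

In this assay, the step of a 6.3-fold lower number from compound 3 to compound 4 (0.80 log units; beyond the scatter) comes from bromo in place of hydrogen, the first change shown on an aromatic carbon of the six-membered aromatic ring of carbon only that is part of the fused system of two rings. It shows that this position, and not only the other aromatic ring, can shift the growth-inhibition number, here with the hydroxy group present. Nothing available explains this shift. As far as these compounds go, whether bromo at this place gives a similar step with the fluoro of compound 2, or with the hydrogen of compound 1, stays open, as does the outcome with chloro, methoxy or an amine there.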